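Chlorophenyl benzylamine against colon cancer cells

A few compounds are considered here, and "the series" means these few. Any claim that something is new, unique, unknown or untested is made for them only; others in the source may bear on it.

Compound 2 `COc1cc(Oc2cccc(Nc3ccccc3)c2)cc(OC)c1CNCCNC(C)=O` gives 11900 nM in a functional assay on SW-620 cells (Homo sapiens) for inhibition, read by MTT assay, with a stated time of 72 h (on this read-out higher numbers stand for weaker inhibition and lower numbers for stronger inhibition), the highest of the two numbers; its nearest neighbour is compound 1 `COc1ccc(CNCc2c(OC)cc(Oc3cccc(Nc4ccccc4)c3)cc2OC)cc1` at 6970 nM. Among the compounds with values here, the only measured step, a 1.7-fold higher number from compound 1 to compound 2 (0.23 log units; within the scatter), covers a change at the same place. Compound 3 `COc1cc(Oc2cccc(Nc3ccccc3)c2)cc(OC)c1CNCc1ccc(Cl)cc1` differs from compound 2 by 4-chlorophenyl in place of acetamidomethyl on a saturated chain carbon bound to an amine nitrogen, which largely reverses that step by restoring an aromatic ring. Compound 3 is therefore expected to land near compound 1, with an expected change of a 1.8-fold lower number from compound 2 to compound 3 (0.26 log units; within the scatter), within the scatter. The estimate for compound 3 is 6500 nM, with a range from 2500 nM to 16000 nM.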

Compound 3, half-maximal inhibitory concentration: 6340 nM
The estimate for compound 3 lay 1.0-fold (0.01 log units) above the measured number, within the range that was stated.
By their numbers in this assay, from the lowest: compounds 3, 1 and 2 (each within the scatter of the next).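

In this assay, 4-chlorophenyl in place of acetamidomethyl on a saturated chain carbon bound to an amine nitrogen gives a 1.9-fold lower number from compound 2 to compound 3 (0.27 log units; within the scatter), so an aromatic ring and the open amide chain are not told apart at this place. Chloro in place of methoxy on an aromatic carbon gives a 1.1-fold lower number from compound 1 to compound 3 (0.04 log units; within the scatter), so this swap on the ring does not separate the two benzylamines either. No measurement on hand offers an explanation for these numbers. Open, from the compounds shown here alone, is whether a carboxylic acid, a primary amine or a longer chain at this place would give a step beyond the scatter.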